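Extending the chain of compound 3 toward a sulfonic acid

A few compounds are considered here, and "the series" means these few. Any claim that something is new, unique, unknown or untested is made for them only; others in the source may bear on it.

Of the compounds shown here, three have been measured in an assay on HEK293 cells for displacement of a labelled ligand from 5-hydroxytryptamine receptor 4 (Homo sapiens), read by scintillation counting; on this read-out higher numbers stand for weaker inhibition and lower numbers for stronger inhibition. Compound 1 `COc1cc(N)c(Cl)cc1C(=O)NCCN1CCNCC1` gives 1260 nM, compound 2 `CC(C)n1c(=O)n(C(=O)NCC2CCNCC2)c2ccccc21` gives 39.8 nM, and compound 3 `CCCCCN1CCC(NC(=O)c2cc(Cl)c(N)cc2OC)CC1` gives 100 nM. Compound 3 therefore stands second highest of the three numbers: its nearest neighbour is compound 2, whose number is lower by a gap beyond the scatter, and the furthest is compound 1, whose number is higher by a gap well beyond the scatter.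

Compound 4 `COc1cc(N)c(Cl)cc1C(=O)NC1CCN(CCCCCCCCS(=O)(=O)O)CC1` has not yet been measured. It keeps the whole of compound 3 and differs only at the far end of the saturated chain, where (3-sulfopropyl in place of hydrogen on a saturated chain carbon, five bonds along the chain from an amine nitrogen in a ring). Put another way, the pentyl chain of compound 3 grows into a longer chain that ends in a sulfonic acid.

Within the data shown here, no pair of measured compounds differs in this single place, so no step of the same kind is available for comparison. A change at the free end of a chain, well away from the amide and the ring nitrogen, is expected to leave the number near that of compound 3, with a modest rise more likely than a fall. The expectation is that the step of a 2.5-fold higher number from compound 3 to compound 4 (0.40 log units; beyond the scatter) stays small, and compound 4 is estimated at 250 nM, within a range from 60 nM to 1000 nM.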

Compound 4, inhibition constant: 15800 nM
Beside the measured number, compound 4's estimate is 63-fold (1.80 log units) below it; the measured number lies above the stated range.
By their numbers in this assay, from the lowest: compound 2; then compound 3; then compound 1; then compound 4.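

In this assay, the far end of the pentyl chain of compound 3 turns out to be a place where a change counts: 3-sulfopropyl in place of hydrogen on a saturated chain carbon, five bonds along the chain from an amine nitrogen in a ring, gives a 160-fold higher number from compound 3 to compound 4 (2.20 log units; beyond the scatter). This is the only step shown between compounds that differ in one place, and it shows that the number can move far beyond the scatter while the amide and the ring nitrogen stay as they were. Nothing available here bears on why the number rises so much.

The change adds length to the chain and places a sulfonic acid at its end in a single step, so these compounds do not show how much of the rise belongs to each. A longer plain alkyl chain with no acid at its end would address the length alone, while a chain of the same length ending in a carboxylic acid or an amine would show how far the rise depends on the sulfonic acid itself.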